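A few compounds are considered here, and "the series" means these few. Any claim that something is new, unique, unknown or untested is made for them only; others in the source may bear on it.

Working notes on the series. The shared core carries a hydroxy-bearing carbon flanked by a sulfonyl arm and an aryl-substituted heteroaromatic ring. Compound 1 `CC(O)(CS(=O)(=O)c1ccccc1)c1nc(-c2ccc(Cl)cc2)no1` and compound 2 `CC(O)(CS(=O)(=O)c1ccc(Cl)cc1)c1nc(-c2ccc(F)c(Cl)c2)no1` have been run in a functional assay on DU-145 cells (Homo sapiens) for cytotoxicity, read by MTT assay; on this read-out lower numbers stand for stronger inhibition and higher numbers for weaker inhibition. For compound 1 the read-out is a limit of the assay, > 100000 nM, with no number behind it. Going by the values given here, compound 2 gives 35500 nM in this assay, the only number so far. Compound 1 alone sits where the assay stops, which is what the limit of > 100000 nM in this assay, at which 1 of the 2 values shown sits, records. The two compounds differ in more than one place, so nothing is computed between them.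

Compound 3 `CC(O)(CS(=O)(=O)c1ccccc1)c1nc(-c2ccc(F)c(Cl)c2)no1` is not yet measured. Against compound 2 the change is hydrogen in place of chloro on an aromatic carbon. Among the compounds with values here, no measured step covers this change; the nearest guide is that compound 1, which also carries an unsubstituted phenyl on the sulfonyl side, returns only the limit > 100000 nM. The expectation is therefore a modest move toward weaker inhibition, with an estimated step from compound 2 to compound 3 of a 2.0-fold higher number from compound 2 to compound 3 (0.29 log units; within the scatter), a real chance of another limit. Compound 3 is estimated at 70000 nM, within 25000 nM to 200000 nM.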

Compound 3, half-maximal inhibitory concentration: > 100000 nM
Compound 3 ended at the assay's limit; the forecaster's own chance of this, stated with the estimate: 40%; at least 1.4-fold (0.15 log units) between middle value and limit.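

Going by these compounds alone, on the sulfonyl side, this pair gives the first readable step for the change from 4-chlorophenyl to phenyl, with everything else held fixed, in this assay: an at least 2.8-fold higher number from compound 2 to compound 3 (0.44 log units; beyond the scatter). This figure is a lower bound and not a size, since one end of the step is a limit, but the step already lies beyond the usual scatter, so the chloro on this aromatic carbon is tied to a real difference between this pair. The step linking compound 1 and compound 3 cannot be read, and the only compound shown that gives a number keeps a chloro on the sulfonyl-side ring, while both compounds with the plain phenyl there stop at the same limit: the limit of > 100000 nM in this assay, at which 2 of the 3 values shown sit.

From the compounds shown here alone, it stays open whether chloro is specifically needed in this place, or whether a methyl, a methoxy group, a bromo or a carboxylic acid there would also bring the read-out within range. Going by these compounds, it is also open whether the chloro has a comparable effect alongside the 4-chlorophenyl on the other side of the core, and how far any such change could improve on compound 2 at 35500 nM.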